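The compounds below may be only part of what the source reports. "The series", "measured", "known", "first", "only" and "open" are said of these compounds alone.

Measured so far:
Compound 1, `O=C(Nc1cc(F)cc(F)c1)N1CCC2(CC1)C(=O)N(C1CC1)C2c1ccc(Cl)cc1`, in an assay on HEK293 cells for inhibition of Voltage-dependent T-type calcium channel subunit alpha-1H (Homo sapiens), read by patch clamp, using a membrane potential dye (on this read-out higher numbers stand for weaker inhibition and lower numbers for stronger inhibition), gives 2260 nM.
Compound 2, `COC(=O)[C@H](C)NC(=O)N1CCC2(CC1)C(=O)N(c1cccc(F)c1)C2c1ccc(Cl)cc1`, in this assay gives 827 nM.

Both compounds share the same core and differ in several places at once, so no single change can be tied to the gap between them; the two numbers only show that compound 2 has the lower of the two values, and the gap to compound 1 lies beyond the usual scatter of repeated measurements.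

Compound 3, `CCC(C)NC(=O)N1CCC2(CC1)C(=O)N(c1cccc(F)c1)C2c1ccc(Cl)cc1`, has not yet been measured in this assay. It departs from compound 2 in one place: sec-butyl in place of 1-(methoxycarbonyl)ethyl on an amide-type nitrogen. The group that leaves carries the ester and its two oxygen atoms; the group that enters is a plain four-carbon chain with no hydrogen-bond donors or acceptors.

For the measured compounds named here, no measured pair shows this particular exchange, so there is no step to lean on. The expectation is a change of no more than the scatter, in either direction, from compound 2 to compound 3, so that compound 3 is estimated at 950 nM, in the range 300 nM to 3000 nM, corresponding to an expected step of a 1.1-fold higher number from compound 2 to compound 3 (0.06 log units; within the scatter).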

Compound 3, half-maximal inhibitory concentration: 1250 nM
Estimate against measurement, compound 3: 1.3-fold (0.12 log units) below; low and high end bracket the measured number.
By their numbers in this assay, from the lowest: compounds 2, 3 and 1 (each within the scatter of the next, the first and the last beyond it).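

For the compounds shown here, compounds 2 and 3 are the only pair here that differ in one place, so a single exchange can be read on its own: in this assay, sec-butyl in place of 1-(methoxycarbonyl)ethyl on an amide-type nitrogen gives a 1.5-fold higher number from compound 2 to compound 3 (0.18 log units; within the scatter). The group that leaves has 6 heavy atoms, 2 hydrogen-bond acceptors and a defined stereocentre, while the group that enters has 4 heavy atoms, all carbon, and 0 hydrogen-bond acceptors. Even so, the two numbers cannot be told apart on this read-out, so on this nitrogen the ester is not needed to keep the number in the range of compound 2, and nothing measured here explains why the exchange leaves so little trace.

The compounds shown leave open whether a carboxylic acid, an amine or a longer chain on the same nitrogen would move the number beyond the scatter. They also leave open whether the mirror-image form of 1-(methoxycarbonyl)ethyl would read the same as the form in compound 2.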